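The compounds below may be only part of what the source reports. "The series", "measured", "known", "first", "only" and "open" are said of these compounds alone.

Measured compounds:
compound 1 `N#CC1=C(N)Oc2c(c3nc4ccccc4nc3c3ccccc23)C12C(=O)N(Cc1cnnn1-c1ccccc1Br)c1ccccc12` — > 50000 nM
compound 2 `N#CC1=C(N)Oc2c(c3nc4ccccc4nc3c3ccccc23)C12C(=O)N(Cc1cnnn1-c1ccc(N)cc1)c1ccccc12` — > 50000 nM
compound 3 `Cc1ccccc1-n1nncc1CN1C(=O)C2(C(C#N)=C(N)Oc3c(N)cc4nc5ccccc5nc4c32)c2ccccc21` — > 50000 nM

In an ADME assay on HUVEC cells (Homo sapiens) for antiproliferative activity, read by MTT assay, with a stated time of 48 h (a lower number here means a stronger inhibitor, a higher number a weaker inhibitor), compound 1 gives only a limit, > 50000 nM. Compound 2 likewise gives only a limit, > 50000 nM. Within the data shown here, compound 3 stands at a limit as well, > 50000 nM; all three sit at the limit of > 50000 nM in this assay, at which 3 of the 3 values shown sit, so no compound can be ranked against another. Among the measured compounds shown here, the one comparable step, a step that the two limits leave unreadable from compound 1 to compound 2, is unreadable, and it is the only step that bears on the change to compound 4 `CCOc1ccc(-n2nncc2CN2C(=O)C3(C(C#N)=C(N)Oc4c(N)cc5nc6ccccc6nc5c43)c3ccccc32)cc1`, which is 4-ethoxyphenyl in place of 2-methylphenyl on an aromatic nitrogen. For the measured compounds named here, no measured step can therefore give a direction or size, and compound 4 is expected to remain at the limit. Compound 4 is expected to give about 50000 nM, in the range 20000 nM to 200000 nM. The estimated step is a number no higher from compound 3 to compound 4 (the limit leaves the size open).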

Compound 4, half-maximal inhibitory concentration: > 50000 nM
Compound 4: only a limit was reported; the forecaster's own chance of this, stated with the estimate: 85%; the middle value sits exactly at the limit.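

Compound 4, like compound 3, gives only a limit, so no step between the two can be read: the limit of > 50000 nM in this assay, at which 4 of the 4 values shown sit.

The compounds shown leave open whether any group on the aromatic nitrogen changes the antiproliferative activity.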